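The source may report more compounds than this note shows. Statements on the series, on what has been measured and on what is new or still open speak of the compounds shown alone.

In a functional assay on PC-12 cells (Rattus norvegicus) for cytotoxicity, read by MTT assay, with stated times of 3 h and 2 h, tested at 50 uM (a higher number here means a stronger effect of the compound at the concentration tested, a lower number a weaker effect), compound 3 `CC(=O)c1cc2ccc(OCCCCCn3cc(CNC(=O)CCCCC4CCSS4)nn3)cc2oc1=O` gives 18.2%, the lowest of the three numbers measured. Its nearest neighbour is compound 1 `O=C(CCCCC1CCSS1)NCc1cn(CCCOc2ccc3cc(-c4ccccc4)c(=O)oc3c2)nn1`, which in this assay gives 23.1%, a gap within the scatter; furthest away lies compound 2 `O=C(CCCCC1CCSS1)NCc1cn(CCCOc2ccc3cc(-c4ccc(Cl)cc4)c(=O)oc3c2)nn1`, which in this assay gives 79.4%, a gap beyond the scatter. Compound 4 `O=C(CCCCC1CCSS1)NCc1cn(CCCCCOc2ccc3cc(-c4ccc(Br)cc4)c(=O)oc3c2)nn1` differs from compound 3 in one place: 4-bromophenyl in place of acetyl on an aromatic carbon.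

Going by the values given here, no measured step pairs an acetyl against a 4-bromophenyl directly. Among the compounds with values here, the one step that bears on the question is the one from compound 1 to compound 2, a number 56.3 percentage points higher from compound 1 to compound 2 (beyond the scatter), where the 4-chlorophenyl end point stood far above both the plain phenyl of compound 1 and the acetyl of compound 3. Compound 4 carries a 4-bromophenyl, the closest analogue of that end point among these compounds, so a large upward step is expected, a number 46.8 percentage points higher from compound 3 to compound 4 (beyond the scatter). For compound 4 the estimate in this assay is therefore 65%, with a range from 35% to 90%, the width reflecting that the inference rests on a single measured step.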

Compound 4, a percentage reported as activity, at one concentration (the size of the read-out at that concentration, not a potency): 53.6%
The estimate for compound 4 lay 11.4 percentage points above the measured number, and the stated range covers the measured number.
By their numbers in this assay, from the lowest: compounds 3 and 1 (each within the scatter of the next); then compound 4; then compound 2.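

At this aromatic carbon, two atoms from the ring oxygen, 4-bromophenyl in place of acetyl gives in this assay a number 35.4 percentage points higher from compound 3 to compound 4 (beyond the scatter) on the shared core. The earlier step changed only a substituent on a phenyl ring already held at this place, whereas this one shows that exchanging the group attached directly to the carbon also moves the read-out, as an acetyl with no ring gives way to an aromatic ring of carbon only. Nothing available here explains this rise.

The whole group changes at once, so the compounds shown cannot separate the share of the aromatic ring from that of the bromine. They also leave open how this assay would respond to a carboxylic acid or an amine at this carbon.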